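From compound 1 to compound 4: an untested change

The source may report more compounds than this note shows. Statements on the series, on what has been measured and on what is new or still open speak of the compounds shown alone.

Compound 1 `CSc1cccc(N2C(=O)CN(c3ccc(C(F)(F)F)cc3)CC2C(=O)NC2CCCC2)c1`: 10000 nM
Compound 2 `CSc1cccc(N2C(=O)CN(c3cc(C(F)(F)F)ccc3C)CC2C(=O)NC2CCCC2)c1`: 10000 nM
Compound 3 `CSc1cccc(N2C(=O)CN(c3cncc(C(F)(F)F)c3)CC2C(=O)NC2CCCC2)c1`: > 50000 nM

These values come from an ADME assay on HepG2 cells (Homo sapiens) for cytotoxicity; on this read-out higher numbers stand for lower toxicity in this test and lower numbers for higher toxicity in this test. The value of compound 3 is a limit of this read-out. Compound 1 sits level with compound 2, as the step of no change at the digits printed from compound 1 to compound 2 (within the scatter) shows. Compound 4 `O=C(NC1CCCC1)C1CN(c2ccc(C(F)(F)F)cc2)CC(=O)N1c1ccc2ccsc2c1` differs from compound 1 by 1-benzothiophen-6-yl in place of 3-(methylsulfanyl)phenyl on an amide-type nitrogen in a ring. The measured steps of an at least 5.0-fold higher number from compound 1 to compound 3 (0.69 log units; beyond the scatter) and an at least 5.0-fold higher number from compound 2 to compound 3 (0.69 log units; beyond the scatter) both alter the group on the amine nitrogen in a ring. None alters the amide-type nitrogen in a ring, so they bear on this change only indirectly. With nothing measured at this place, the expected outcome is no change at the digits printed from compound 1 to compound 4 (within the scatter), with no step beyond the scatter. For compound 4 the estimated value is 10000 nM, expected to lie from 4000 nM to 30000 nM.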

Compound 4, half-maximal cytotoxic concentration: 10000 nM
Compound 4: middle estimate and measured number agree at the digits printed; the measured number falls inside the stated range.
By their numbers in this assay, from the lowest: compounds 1, 2 and 4 (each within the scatter of the next). At a limit, above all of these: compound 3.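

For the compounds shown here, for the first time, a step in this assay reaches the amide-type nitrogen in a ring: no change at the digits printed from compound 1 to compound 4 (within the scatter). Going by these compounds alone, at this position, 1-benzothiophen-6-yl, which adds a five-membered aromatic ring, replaces 3-(methylsulfanyl)phenyl with no shift beyond the scatter, whereas the earlier steps touched only the amine nitrogen in a ring. Nothing measured here accounts for this outcome.

From the compounds shown here alone, it remains open whether a pyridine ring or a carboxylic acid at this nitrogen would move the number. Also open, going by these compounds, is how 1-benzothiophen-6-yl would behave alongside the 5-(trifluoromethyl)pyridin-3-yl group of compound 3.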